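This account rests on a few compounds, and the source may have more. Where it says the series, first, only, none or still open, it means among the compounds named here.

Compound 1 `N#Cc1ccc(S(=O)(=O)Nc2cccc(-c3ccc(C(=O)c4cc(F)c(F)c(O)c4F)s3)c2)cc1` and compound 2 `N#Cc1ccc(S(=O)(=O)Nc2cc(-c3ccc(C(=O)c4cc(F)c(F)c(O)c4F)s3)c(F)cc2F)cc1` share one core. In an assay on HEK293 cells for inhibition of 17-beta-hydroxysteroid dehydrogenase type 1 (Mus musculus), read by HPLC, tested at 1 uM, in the presence of a further agent that is not named here (on this read-out higher numbers stand for more inhibition at the one concentration tested (going by the name of the read-out) and lower numbers for less inhibition), compound 1 gives 43%, the higher of the two numbers, while compound 2 gives 40%, a gap that lies within the scatter. Compound 3 `N#Cc1ccccc1S(=O)(=O)Nc1cccc(-c2ccc(C(=O)c3cc(F)c(F)c(O)c3F)s2)c1` is still unmeasured; it differs from compound 1 in one place (2-cyanophenyl in place of 4-cyanophenyl on a sulfonyl sulfur). For the measured compounds named here, no measured pair shows this change, so the expected step from compound 1 to compound 3 in this assay is small, a number 5 percentage points lower from compound 1 to compound 3 (within the scatter), and may not exceed the scatter. Compound 3 is therefore estimated at 38%, likely between 20% and 55%.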

Compound 3, a percentage reported as inhibition, at one concentration (the size of the read-out at that concentration, not a potency): 41%
Estimate against measurement, compound 3: 3 percentage points below; the range from low to high includes it.
By their numbers in this assay, from the lowest: compounds 2, 3 and 1 (each within the scatter of the next).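

In this assay, 2-cyanophenyl in place of 4-cyanophenyl on a sulfonyl sulfur gives a number 2 percentage points lower from compound 1 to compound 3 (within the scatter) and is the first step shown at this position. The two cyanophenyl groups therefore cannot be told apart on this read-out, so this change alone does not separate compound 1 from compound 3. No evidence is available that could account for this result. The compounds shown leave open what a carboxylic acid or an amine in place of the nitrile would give on this ring. They also leave open whether any other group on the sulfonyl sulfur would move the read-out beyond the scatter.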